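From tert-Butoxycarbonyl to Benzyloxycarbonyl: an Expected Step

A few compounds are considered here, and "the series" means these few. Any claim that something is new, unique, unknown or untested is made for them only; others in the source may bear on it.

Compound 1 `Cc1cc(NC(=O)CC(C)(C)C)nn1Cc1cc(Cl)ccc1OCc1ccccc1`: 10 nM
Compound 2 `Cc1cc(NC(=O)OC(C)(C)C)nn1Cc1cc(Cl)ccc1OCc1ccccc1`: 25.1 nM

Both compounds were tested in an assay on CHO-K1 cells for displacement of a labelled ligand from prostaglandin E2 receptor EP1 subtype (Homo sapiens); on this read-out lower numbers stand for stronger inhibition and higher numbers for weaker inhibition. Within the data shown here, compound 2 gives the higher of the two numbers; the one measured step leading to it, a 2.5-fold higher number from compound 1 to compound 2 (0.40 log units; beyond the scatter), is modest but beyond the scatter. Compound 3 `Cc1cc(NC(=O)OCc2ccccc2)nn1Cc1cc(Cl)ccc1OCc1ccccc1` differs from compound 2 by benzyl in place of tert-butyl on an oxygen next to a carbonyl group. Among the measured compounds shown here, no measured step changes the group on this oxygen, and the only step on hand, a 2.5-fold higher number from compound 1 to compound 2 (0.40 log units; beyond the scatter), is a different change at the same carbonyl, so it shows merely that this side of the carbonyl tolerates change without giving a direction. For compound 3 the expected outcome is therefore a number close to that of compound 2, with wide uncertainty. The expected step is a 1.6-fold higher number from compound 2 to compound 3 (0.20 log units; within the scatter), not clearly beyond the scatter. The estimate for compound 3 is 40 nM, within a range from 10 nM to 160 nM.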

Compound 3, half-maximal inhibitory concentration: 79.4 nM
Compound 3: middle estimate off by 2.0-fold (0.30 log units), on the low side; the measured number falls inside the stated range.
By their numbers in this assay, from the lowest: compound 1; then compound 2; then compound 3.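

In this assay, among these compounds, the group on this oxygen turns out to matter in its own right: benzyl in place of tert-butyl gives a 3.2-fold higher number from compound 2 to compound 3 (0.50 log units; beyond the scatter) and this is the first measured change at that atom. Benzyloxy in place of neopentyl on the carbonyl carbon gives a 7.9-fold higher number from compound 1 to compound 3 (0.90 log units; beyond the scatter) and so the side of the carbonyl that had merely tolerated change now shows a direction, with the number rising from neopentyl through tert-butoxy to benzyloxy and none of the three compounds going against that order. Nothing available accounts for this rise.

The compounds shown leave open whether the aromatic ring of benzyl or its larger count of carbons goes with the weaker inhibition. A cyclohexylmethyl group or a plain methyl on the same oxygen would bear on that question.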